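Swapping a dichlorophenyl group for an indole group

The source may report more compounds than this note shows. Statements on the series, on what has been measured and on what is new or still open speak of the compounds shown alone.

Among the measured compounds shown here, in a functional assay on DU-145 cells (Homo sapiens) for inhibition, read by trypan blue exclusion, with a stated time of 96 h (a lower number here means a stronger inhibitor of growth, a higher number a weaker inhibitor of growth), compound 2 `Cc1ccc(S/C(=C/c2ccc(Cl)cc2Cl)C(=O)c2ccc(Cl)cc2)cc1` stands at 10000 nM, the higher and so the weaker of the two numbers measured so far. For the measured compounds named here, the only other measured compound, compound 1 `Cc1ccc(S/C(=C/c2c[nH]c3ccc(Cl)cc23)C(=O)c2ccc(Cl)cc2)cc1`, gives 1000 nM, a gap beyond the usual scatter of repeated measurements.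

The next compound, compound 3 `Cc1ccc(S/C(=C/c2c[nH]c3ccccc23)C(=O)c2ccc(Cl)cc2)cc1`, keeps the rest of compound 2 and changes one group: 1H-indol-3-yl in place of 2,4-dichlorophenyl on a double-bonded chain carbon bound to a double-bonded chain carbon. Here 1H-indol-3-yl comes in place of 2,4-dichlorophenyl on a double-bonded chain carbon bound to a double-bonded chain carbon.

Compound 1 carries a chlorine-bearing version of the 1H-indol-3-yl group at that place and reaches 1000 nM, so compound 3 is expected to land closer to compound 1 than to compound 2. Going by the values given here, no measured pair shows what losing that chlorine does, so the expectation stays broad. The expected change, a 6.7-fold lower number from compound 2 to compound 3 (0.82 log units; beyond the scatter), is a move to a lower number in this assay, beyond the scatter. The estimate for compound 3 is 1500 nM, with an expected range of 400 nM to 6000 nM.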

Compound 3, concentration for 50% growth inhibition: 10000 nM
The estimate for compound 3 lay 6.7-fold (0.82 log units) below the measured number, and the stated range ends below it.
By their numbers in this assay, from the lowest: compound 1; then compounds 2 and 3 (each within the scatter of the next).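

In this assay, 1H-indol-3-yl in place of 2,4-dichlorophenyl gives no change at the digits printed from compound 2 to compound 3 (within the scatter), so at this place on the double-bonded chain carbon, the plain indole group performs no differently from the dichlorophenyl group. The lower number of compound 1 therefore cannot be credited to the indole group alone: hydrogen in place of chloro on an aromatic carbon of that indole gives a 10-fold higher number from compound 1 to compound 3 (1.00 log units; beyond the scatter), a step beyond the scatter, which ties the stronger growth inhibition of compound 1 to the presence of that single chlorine. No supporting measurement is available to explain why removing the chlorine has this effect.

The compounds shown leave open whether the chlorine is uniquely suited to this aromatic carbon, or whether fluoro, bromo, methyl or methoxy in the same place would also keep the lower number. They also leave open whether an amine or a carboxylic acid there would give a number like that of compound 1 or one like that of compound 3.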